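Fluoro substitution on the hydroxymethyl-bearing ring of compound 3

This account rests on a few compounds, and the source may have more. Where it says the series, first, only, none or still open, it means among the compounds named here.

Compound 3 `Nc1nc(NCCCc2ccccc2)nc(-c2ccccc2CO)n1` stands highest of the three compounds measured in a functional assay on cells for positive allosteric modulation of G-protein coupled receptor 68 (Homo sapiens), read by a luciferase reporter and cAMP accumulation, with a stated time of 30 min, at pH 6.8 and pH 8.3, in the presence of a further agent that is not named here (on this read-out lower numbers stand for lower potency and higher numbers for higher potency (the scale is a negative logarithm)), where compound 3 gives 5.22. Compound 1 `Nc1nc(NCc2cccc(F)c2)nc(-c2ccccc2CO)n1` gives 4.52 and compound 2 `Nc1nc(NCc2ccc(F)cc2)nc(-c2ccccc2CO)n1` gives 3.97; the steps of a number 0.70 log units higher from compound 1 to compound 3 (beyond the scatter) and a number 1.25 log units higher from compound 2 to compound 3 (beyond the scatter) both concern the chain on the nitrogen, not the ring carrying the hydroxymethyl group. Compound 4 `Nc1nc(NCCCc2ccccc2)nc(-c2c(F)cccc2CO)n1` differs from compound 3 by fluoro in place of hydrogen on an aromatic carbon, on an aromatic carbon of a six-membered aromatic ring of carbon only, ortho to a large group and meta to a hydroxymethyl group. Among the compounds with values here, no measured step places a fluoro on this ring; the only fluoro comparison, a number 0.55 log units lower from compound 1 to compound 2 (beyond the scatter), concerns the other ring. A step of a number 0.02 log units lower from compound 3 to compound 4 (within the scatter) within the scatter is therefore expected. Compound 4 is estimated at 5.2, between 4.6 and 5.8.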

Compound 4, negative logarithm of the antagonist equilibrium constant: 4.47
Estimate against measurement, compound 4: 0.73 log units above; the measured number lies below the stated range.
By their numbers in this assay, from the lowest: compound 2; then compounds 4 and 1 (each within the scatter of the next); then compound 3.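

Fluoro in place of hydrogen ortho to a large group and meta to a hydroxymethyl group gives a number 0.75 log units lower from compound 3 to compound 4 (beyond the scatter) in this assay and so this position of the series is sensitive to even a single added fluoro. Within the data shown here, the earlier steps all concerned the chain on the nitrogen, and this is the first showing that the ring carrying the hydroxymethyl group also moves the read-out. No measurement at hand accounts for the drop.

Open, on these data alone, is whether chloro, methyl or methoxy at this position gives a similar step. Also open, as far as these compounds go, is whether fluoro elsewhere on this ring behaves the same way.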